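A few compounds are considered here, and "the series" means these few. Any claim that something is new, unique, unknown or untested is made for them only; others in the source may bear on it.

Working notes on the series. In a functional assay on LS174T cells (Homo sapiens) for inhibition, with a stated time of 4 days, tested at 1 uM (a higher number here means a stronger effect of the compound at the concentration tested, a lower number a weaker effect), compound 1 `CN(C)c1ccc2cc(C#Cc3c(F)cccc3F)ccc2n1` gives 2%, and compound 2 `Fc1cccc(F)c1C#Cc1ccc2ncccc2c1` gives 11%; the step of a number 9 percentage points higher from compound 1 to compound 2 (within the scatter) lies within the scatter. Of the two numbers shown, compound 2 is not set apart: its gap to compound 1 is within the scatter. Compound 3 `Fc1cccc(F)c1C#Cc1ccc2nc(Cl)ccc2c1` differs from compound 2 by chloro in place of hydrogen on an aromatic carbon. For the measured compounds named here, no measured step puts a chloro in place of hydrogen; the only step measured, a number 9 percentage points higher from compound 1 to compound 2 (within the scatter), concerns another position and is small, so no change beyond the scatter is expected in this assay. The expected step is a number 4 percentage points higher from compound 2 to compound 3 (within the scatter). Compound 3 is estimated at 15%, between 0% and 35%.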

Compound 3, a percentage reported as inhibition, at one concentration (the size of the read-out at that concentration, not a potency): 21.2%
Beside the measured number, compound 3's estimate is 6.2 percentage points below it; measured number inside the range.
By their numbers in this assay, from the lowest: compounds 1 and 2 (each within the scatter of the next); then compound 3.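

In this assay, chloro on the aromatic carbon next to the ring nitrogen gives a step beyond the scatter, a number 10.2 percentage points higher from compound 2 to compound 3 (beyond the scatter), so this carbon responds to substitution. Chloro in place of dimethylamino on the same carbon gives a number 19.2 percentage points higher from compound 1 to compound 3 (beyond the scatter), though both steps remain modest. Nothing available here accounts for the change.

Going by these compounds, whether the rise extends to other groups on this carbon, such as fluoro, methoxy or a primary amine, stays open. Also open, on these data alone, is whether any group here gives more than a modest step.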